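Cyclopentyl in Place of tert-Butyl: What to Expect

The source may report more compounds than this note shows. Statements on the series, on what has been measured and on what is new or still open speak of the compounds shown alone.

Compound 1, `Cc1ccc2c(c1)c(=O)c(C(=O)Nc1ccc(Oc3ncnc4[nH]cc(-c5ccccc5)c34)c(F)c1)c(C)n2C`, in an assay on isolated protein for inhibition of tyrosine-protein kinase receptor UFO (Homo sapiens), read by FRET and Z'-LYTE, with a stated time of 1.5 h; on this read-out higher numbers stand for weaker inhibition and lower numbers for stronger inhibition: 100 nM
Compound 2, `C=C(C)c1ccc2c(c1)c(=O)c(C(=O)Nc1ccc(Oc3ncnc4[nH]cc(-c5ccccc5)c34)c(F)c1)c(C)n2C`, in this assay: 170 nM
Compound 3, `Cc1c(C(=O)Nc2ccc(Oc3ncnc4[nH]cc(-c5ccccc5)c34)c(F)c2)c(=O)c2cc(C(C)(C)C)ccc2n1C`, in this assay: 42 nM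

These three share one core and differ only in the group on one aromatic carbon. Compound 3 has the lowest number of the three: the steps of a 2.4-fold lower number from compound 1 to compound 3 (0.38 log units; beyond the scatter) and a 4.0-fold lower number from compound 2 to compound 3 (0.61 log units; beyond the scatter) both lie beyond the scatter, while a 1.7-fold higher number from compound 1 to compound 2 (0.23 log units; within the scatter) does not.

Compound 4, `Cc1c(C(=O)Nc2ccc(Oc3ncnc4[nH]cc(-c5ccccc5)c34)c(F)c2)c(=O)c2cc(C3CCCC3)ccc2n1C`, differs from compound 3 by cyclopentyl in place of tert-butyl on an aromatic carbon. For the measured compounds named here, no measured step involves a cyclopentyl, so only the three steps at this same carbon bear on it, and they are all modest. The step from compound 3 to compound 4 is therefore expected to stay within the scatter: a 1.1-fold lower number from compound 3 to compound 4 (0.02 log units; within the scatter). Compound 4 is estimated at 40 nM, with a range from 15 nM to 110 nM.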

Compound 4, half-maximal inhibitory concentration: 200 nM
Compound 4: middle estimate off by 5.0-fold (0.70 log units), on the low side; the whole stated range lies below it.
By their numbers in this assay, from the lowest: compound 3; then compounds 1, 2 and 4 (each within the scatter of the next).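

At this carbon, a modest change in the carbon group matters: swapping tert-butyl for cyclopentyl gives a 4.8-fold higher number from compound 3 to compound 4 (0.68 log units; beyond the scatter). The other two steps, a 1.2-fold higher number from compound 2 to compound 4 (0.07 log units; within the scatter) and a 2.0-fold higher number from compound 1 to compound 4 (0.30 log units; within the scatter), stay within the scatter, so in this assay only the tert-butyl compound stands apart from the other three. No evidence here accounts for this difference.

Still open, going by these compounds, is whether the advantage belongs to tert-butyl alone. Isopropyl, cyclopropyl or cyclohexyl at this carbon would show whether other branched or ring groups keep it or lose it.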